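Swapping bromo for nitro on compound 1

The source may hold more compounds than are shown below. What is called first, only, known or untested is meant among the compounds shown, and "the series" means these compounds.

Among the compounds with values here, in a functional assay on the whole organism with Mus musculus as the target (a lower number here means that less compound is needed, a higher number that more compound is needed for the effect), compound 1 `COc1cc2c(cc1OC)C(c1ccc(Br)cc1)=NNC(=O)C2` gives 110 umol/kg, the only exact number available. Compound 2 `COc1cc2c(cc1OC)C(c1cccc([N+](=O)[O-])c1)=NNC(=O)C2` is recorded only as a limit of the assay, > 120 umol/kg. Compound 3 `COc1cc2c(cc1OC)C(c1ccc([N+](=O)[O-])cc1)=NNC(=O)C2` carries nitro in place of bromo on an aromatic carbon, para to a large group (nitro in place of bromo on an aromatic carbon). Within the data shown here, no measured pair of compounds shows this change directly. The step expected in this assay is small, a 1.1-fold higher number from compound 1 to compound 3 (0.04 log units; within the scatter), within the usual scatter and with no firm direction. For compound 3 the estimated dose is 120 umol/kg, with an expected range of 60 umol/kg to 240 umol/kg.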

Compound 3, dose for half-maximal effect: > 120 umol/kg
Compound 3: a limit, no number; the forecaster's own chance of this, stated with the estimate: 30%; the middle value lies on the limit itself.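

Nitro in place of bromo on an aromatic carbon, para to a large group, now has a direct reading in this assay: an at least 1.0-fold higher number from compound 1 to compound 3 (0.03 log units; that floor lies within the scatter). Compound 3 is recorded only as a limit, so this step is a floor and not a measured size. The floor says little about the change, because the reading stops at the same limit that compound 2 reaches: the limit of > 120 umol/kg in this assay, at which 2 of the 3 values shown sit.

On these data alone, how far compound 3 actually lies from compound 1 stays open. So does whether an amine or a carboxylic acid on this carbon would give an exact number in this assay.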